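This account rests on a few compounds, and the source may have more. Where it says the series, first, only, none or still open, it means among the compounds named here.

Measured compounds:
Compound 1 `CNC(=O)[C@H](c1ccc(Cl)cc1)C(C)C`; in a functional assay on CHO cells for agonist activity at Free fatty acid receptor 2 (Homo sapiens), read by cAMP accumulation (a lower number here means a stronger inhibitor, a higher number a weaker inhibitor), compound 1 gives 11000 nM.
Compound 2 `CC(C)[C@H](C(=O)Nc1ccccc1)c1ccc(Cl)cc1`; in this assay compound 2 gives only a limit of the assay, > 100000 nM.
Compound 3 `CC(C)[C@H](C(=O)Nc1ncns1)c1ccc(Cl)cc1`; in this assay compound 3 gives 2000 nM.

Compound 3 stands lowest of the two numbers, with compound 1 nearest: the step of a 5.5-fold lower number from compound 1 to compound 3 (0.74 log units; beyond the scatter) was modest, and the step of an at least 50-fold lower number from compound 2 to compound 3 (1.69 log units; beyond the scatter) was large. Compound 4 `CC(C)[C@H](C(=O)Nc1cnns1)c1ccc(Cl)cc1` differs from compound 3 by 1,2,3-thiadiazol-5-yl in place of 1,2,4-thiadiazol-5-yl on an amide-type nitrogen. Among the compounds with values here, both measured steps concern the arrival of the 1,2,4-thiadiazol-5-yl itself; no measured step compares two thiadiazole isomers, so the change is expected to be small, within the scatter, as a 1.5-fold higher number from compound 3 to compound 4 (0.18 log units; within the scatter). Compound 4 is therefore estimated at 3000 nM in this assay, expected between 1000 nM and 10000 nM.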

Compound 4, half-maximal inhibitory concentration: 57000 nM
Estimate against measurement, compound 4: 19-fold (1.28 log units) below; measured number above the stated range.
By their numbers in this assay, from the lowest: compound 3; then compound 1; then compound 4. At a limit, above all of these: compound 2.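

With the same atoms joined differently, the ring on this amide-type nitrogen still matters: 1,2,3-thiadiazol-5-yl in place of 1,2,4-thiadiazol-5-yl is a large step, a 29-fold higher number from compound 3 to compound 4 (1.45 log units; beyond the scatter). The 1,2,3-thiadiazol-5-yl also falls behind plain methyl, with a 5.2-fold higher number from compound 1 to compound 4 (0.71 log units; beyond the scatter), so among these compounds the gain belongs to the 1,2,4-thiadiazol-5-yl and not to thiadiazoles in general. Against phenyl the step is only a floor: an at least 1.7-fold lower number from compound 2 to compound 4 (0.24 log units; that floor lies within the scatter). Compound 2 stands at a limit of the assay: the limit of > 100000 nM in this assay, at which 1 of the 4 values shown sits.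

The compounds shown leave open how other five-membered rings on this nitrogen, such as a thiazole or an oxadiazole, would compare. They also do not say why the two thiadiazole isomers differ.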